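The source may hold more compounds than are shown below. What is called first, only, known or untested is meant among the compounds shown, and "the series" means these compounds.

In an ADME assay on 2209-23 cells (Homo sapiens) for cytotoxicity, read by WST assay and thymidine incorporation (on this read-out higher numbers stand for lower toxicity in this test and lower numbers for higher toxicity in this test), compound 2 `CC(C)(C)[C@H]1C(O)=C(C2=CS(=O)(=O)c3cc(NS(C)(=O)=O)ccc3N2)C(=O)N1Cc1ccc(F)cc1` gives > 50000 nM, which is a limit and not a number. Compound 1 `CC(=O)C1=C(C2=C(O)[C@H](C(C)(C)C)N(Cc3ccc(F)cc3)C2=O)Nc2ccc(NS(C)(=O)=O)cc2S1(=O)=O` gives > 50000 nM, also a limit. Compound 3 `CC(C)(C)[C@H]1C(O)=C(C2=CS(=O)(=O)c3cc(NS(C)(=O)=O)ccc3N2)C(=O)N1Cc1ccc(F)c(Cl)c1` gives > 50000 nM, again a limit. The three compounds share (the limit of > 50000 nM in this assay, at which 3 of the 3 values shown sit). Compound 4 `CC(C)(C)[C@H]1C(O)=C(C2=CS(=O)(=O)c3cc(NS(C)(=O)=O)cc(F)c3N2)C(=O)N1Cc1ccc(F)cc1` differs from compound 2 by fluoro in place of hydrogen on an aromatic carbon. Two measured changes bear on this: chloro in place of hydrogen on an aromatic carbon is a step that the two limits leave unreadable from compound 2 to compound 3, and hydrogen in place of acetyl on a double-bonded ring carbon is a step that the two limits leave unreadable from compound 1 to compound 2. Neither gives a size, so no step beyond the scatter is expected in this assay, and a further limit is the likely outcome. Compound 4 is expected at 60000 nM, with an estimated range of 25000 nM to 100000 nM.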

Compound 4, half-maximal cytotoxic concentration: > 50000 nM
Compound 4 was reported as a limit; the forecaster's own chance of this, stated with the estimate: 85%; the middle value is on the limit's open side.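

Compound 2 and compound 4 both stand as limits in this assay, so no size can be read for fluoro in place of hydrogen on an aromatic carbon. The compounds shown leave open the actual half-maximal cytotoxic concentration of each compound, as all rest on one limit: the limit of > 50000 nM in this assay, at which 4 of the 4 values shown sit.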